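The source may report more compounds than this note shows. Statements on the series, on what has been measured and on what is new or still open speak of the compounds shown alone.

Compound 1, `CC(C)C(/C=C1\NC(=O)NC1=O)c1ccc(-c2ccc3cccc(F)c3c2)[nH]c1=O`, gives 87 nM in a functional assay on CHO cells for antagonist activity at prostaglandin E2 receptor EP3 subtype (Homo sapiens), read by cAMP accumulation, with a stated time of 30 min; on this read-out lower numbers stand for stronger inhibition and higher numbers for weaker inhibition. Compound 2, `CC(C)C(CC1NC(=O)NC1=O)c1ccc(-c2ccc3cccc(F)c3c2)[nH]c1=O`, gives 31 nM. Compound 3, `CCn1ncc2c(F)cc(-c3ccc(C(/C=C4\OC(=O)NC4=O)(CC)CC)c(=O)[nH]3)cc21`, gives 33 nM.

Among these three numbers compound 2 holds the lowest, though compound 3 sits within the scatter of it, so the two cannot be ranked; compound 1 stands beyond the scatter above both. Compound 4, `CC(C)C(c1ccc(-c2ccc3cccc(F)c3c2)[nH]c1=O)C1NC(=O)NC1=O`, is not yet measured. It differs from compound 2 by 2,5-dioxoimidazolidin-4-yl in place of (2,5-dioxoimidazolidin-4-yl)methyl on a saturated chain carbon bound to an aromatic carbon and a saturated chain carbon. Among the compounds with values here, the one measured step concerning the same part of the molecule, a 2.8-fold lower number from compound 1 to compound 2 (0.45 log units; beyond the scatter), was modest, but the change in compound 4 is of a different kind, so no measured step predicts its size directly. For compound 4 a shift within or near the scatter is expected, a 1.5-fold higher number from compound 2 to compound 4 (0.16 log units; within the scatter), with wide uncertainty. The estimate for compound 4 is 45 nM, ranging from 15 nM to 150 nM.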

Compound 4, half-maximal inhibitory concentration: 320 nM
Compound 4: middle estimate off by 7.1-fold (0.85 log units), on the low side; measured number outside the range, above it.
By their numbers in this assay, from the lowest: compounds 2 and 3 (each within the scatter of the next); then compound 1; then compound 4.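

In this assay, replacing (2,5-dioxoimidazolidin-4-yl)methyl with 2,5-dioxoimidazolidin-4-yl gives a 10-fold higher number from compound 2 to compound 4 (1.01 log units; beyond the scatter), and the step from the unsaturated link gives a 3.7-fold higher number from compound 1 to compound 4 (0.57 log units; beyond the scatter). So at this place the length of the link to the ring counts for more than its saturation, which was all the earlier step could show. Nothing measured here explains this loss.

On these data alone, whether a longer chain would match or improve on the methyl link remains open. So does whether an amine or a carboxylic acid could replace the ring.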